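A few compounds are considered here, and "the series" means these few. Any claim that something is new, unique, unknown or untested is made for them only; others in the source may bear on it.

For the measured compounds named here, in an ADME assay on BEAS-2B cells (Homo sapiens) for cytotoxicity, read by MTT assay, with a stated time of 72 h (a lower number here means a stronger inhibitor of growth, a higher number a weaker inhibitor of growth), compound 3 `COc1ccc(CNc2nc(SC)nc3ccccc23)cc1` gives 96200 nM, the only plain number among the three values shown. Compound 1 `COc1ccc(CNc2nc([Se]C)nc3ccccc23)cc1` returns the assay limit > 100000 nM rather than a number. Compound 2 `COc1ccc(CNc2nc([SeH])nc3ccccc23)cc1` likewise sits at the limit > 100000 nM. The step from compound 3 to compound 4 `COc1ccc(CNc2nc(S)nc3ccccc23)cc1` is hydrogen in place of methyl on a sulfur. The nearest measured counterpart, a step that the two limits leave unreadable from compound 1 to compound 2, cannot be read because the limit of > 100000 nM in this assay, at which 2 of the 3 values shown sit, applies to both compounds in it. The other steps, an at least 1.0-fold lower number from compound 1 to compound 3 (0.01 log units; that floor lies within the scatter) and an at least 1.0-fold lower number from compound 2 to compound 3 (0.01 log units; that floor lies within the scatter), are floors that lie within the scatter. Nothing measured therefore points to a step beyond the scatter, and the expected step is a 1.1-fold higher number from compound 3 to compound 4 (0.06 log units; within the scatter). Compound 4 is estimated at 110000 nM, with a range from 45000 nM to 270000 nM, and may well land at the limit again.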

Compound 4, concentration for total growth inhibition: 32500 nM
Estimate against measurement, compound 4: 3.4-fold (0.53 log units) above, outside the stated range (below it).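

In this assay, for the compounds shown here, taking the methyl off the sulfur gives the first step at this position that reads beyond the scatter: a 3.0-fold lower number from compound 3 to compound 4 (0.47 log units; beyond the scatter). The sulfanyl compound also separates from both selenium compounds, with an at least 3.0-fold lower number from compound 2 to compound 4 (0.48 log units; beyond the scatter) and an at least 3.0-fold lower number from compound 1 to compound 4 (0.48 log units; beyond the scatter). These two steps are floors and not exact sizes, because compound 1 and compound 2 stand at a limit: the limit of > 100000 nM in this assay, at which 2 of the 4 values shown sit.

From the compounds shown here alone, how a longer chain, a carboxylic acid or an amine on this sulfur would read remains open. So does the true size of the gap between the sulfur and selenium compounds.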